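Swapping the ether for a direct cyclohexyl on the tert-butyl ring

The source may hold more compounds than are shown below. What is called first, only, known or untested is meant among the compounds shown, and "the series" means these compounds.

Compound 1 `CC(C)COc1cc(C(C)(C)C)ccc1CNC(=O)C(C)c1ccc(NS(C)(=O)=O)c(F)c1` gives 2.1 nM in an assay on cells for antagonist activity at transient receptor potential cation channel subfamily V member 1 (Homo sapiens), read by FLIPR and calcium flux, with a stated time of 6 min (a higher number here means a weaker inhibitor, a lower number a stronger inhibitor), and compound 2 `CC(C(=O)NCc1ccc(C(C)(C)C)cc1OCc1ccccc1)c1ccc(NS(C)(=O)=O)c(F)c1` gives 2.9 nM. Within the data shown here, compound 2 holds the higher of the two numbers, with compound 1 nearest, and the only step between them, a 1.4-fold higher number from compound 1 to compound 2 (0.14 log units; within the scatter), stays within the scatter. Compound 3 `CC(C(=O)NCc1ccc(C(C)(C)C)cc1C1CCCCC1)c1ccc(NS(C)(=O)=O)c(F)c1` differs from compound 2 thus: cyclohexyl in place of benzyloxy on an aromatic carbon. Among the measured compounds shown here, no measured step touches this change; the one known step only traded groups within the ether. Compound 3 is therefore expected to give 10 nM, between 2 nM and 50 nM. That estimate means a step of a 3.4-fold higher number from compound 2 to compound 3 (0.54 log units; beyond the scatter), a likely loss that remains uncertain.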

Compound 3, inhibition constant: 9.8 nM
Beside the measured number, compound 3's estimate is 1.0-fold (0.01 log units) above it; the measured number falls inside the stated range.
By their numbers in this assay, from the lowest: compounds 1 and 2 (each within the scatter of the next); then compound 3.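

Earlier, only the group on the ether oxygen had changed, and that left the number within the scatter. At this aromatic carbon, losing the ether altogether has a modest but real cost in this assay for both replacements: cyclohexyl for benzyloxy (a 3.4-fold higher number from compound 2 to compound 3 (0.53 log units; beyond the scatter)) and cyclohexyl for isobutoxy (a 4.7-fold higher number from compound 1 to compound 3 (0.67 log units; beyond the scatter)). Nothing available explains this loss.

The compounds shown leave open whether the ether oxygen or the ring type accounts for the step. A cyclohexyloxy group or a piperidine amine at this carbon would address that question.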